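Imidazoline ethers: five-membered heteroaryl swap at the ortho position

The source may hold more compounds than are shown below. What is called first, only, known or untested is meant among the compounds shown, and "the series" means these compounds.

Compound 2 `c1ccc(-c2cc[nH]n2)c(OCC2=NCCN2)c1` is the reference point here. In a functional assay for activation of Alpha-1D adrenergic receptor (Homo sapiens), read by calcium flux (a lower number here means that less compound is needed, a higher number that more compound is needed for the effect), compound 2 gives < 100000 nM, which is a limit of the assay and not a number. Within the data shown here, compound 1 `c1ccc(-c2ccncn2)c(OCC2=NCCN2)c1` is the only other measured member. In this assay compound 1 likewise gives < 100000 nM, again a limit. Among the measured compounds shown here, the one measured step, a step that the two limits leave unreadable from compound 1 to compound 2, is therefore of unreadable size, since the limit of < 100000 nM in this assay, at which 2 of the 2 values shown sit, covers both values shown.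

Compound 3 `c1ccc(-c2ccns2)c(OCC2=NCCN2)c1` differs from compound 2 by 1,2-thiazol-5-yl in place of 1H-pyrazol-3-yl on an aromatic carbon. For the measured compounds named here, no measured step bears on this change: the step from compound 1 to compound 2 is a heteroaryl swap at the same position, but its size is not readable. Going by the values given here, the expectation for compound 3 thus rests on no step, only on the two limits. The step from compound 2 to compound 3 is expected to be about a step that the limit leaves unreadable from compound 2 to compound 3, with no direction justified. Compound 3 is estimated in this assay at 20000 nM, within a range from 2000 nM to 100000 nM.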

Compound 3, half-maximal effective concentration: 25.1 nM
Estimate against measurement, compound 3: 800-fold (2.90 log units) above; measured number outside the range, below it.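

No step to compound 3 can be read in this assay, from either compound 1 or compound 2, because both of those compounds give only a limit of the assay: the limit of < 100000 nM in this assay, at which 2 of the 3 values shown sit.

The compounds shown leave open how large either step to compound 3 really is.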